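Swapping Bromine for an Ethynyl Group on a Thiazole

A few compounds are considered here, and "the series" means these few. Any claim that something is new, unique, unknown or untested is made for them only; others in the source may bear on it.

Of the compounds shown here, two that share a core have been measured. Compound 1 `Cc1nc(C#Cc2cccc(Cl)c2)cs1` gives 129 nM in a functional assay on CHO cells for agonist activity at metabotropic glutamate receptor 5 (Homo sapiens), read by inositol phosphate accumulation; on this read-out higher numbers stand for weaker inhibition and lower numbers for stronger inhibition. Compound 2 `Fc1cccc(C#Cc2csc(Br)n2)c1` gives 526 nM in this assay, the higher of the two numbers; the gap between compound 1 and compound 2 lies beyond the usual scatter, so compound 2 is the weaker inhibitor of the pair. The two differ in more than one place, so no single change can be credited with that gap.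

Compound 3 `C#Cc1nc(C#Cc2cccc(F)c2)cs1` is not yet measured. It arises from compound 2 by one change: ethynyl in place of bromo on an aromatic carbon. Among the measured compounds shown here, nothing among the measured compounds shows what this exchange does, so the direction is open. The step from compound 2 to compound 3 in this assay is expected to be small, a 1.6-fold lower number from compound 2 to compound 3 (0.22 log units; within the scatter), possibly within the scatter. Compound 3 is therefore estimated at 320 nM in this assay, within a range from 80 nM to 1300 nM.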

Compound 3, half-maximal inhibitory concentration: 2920 nM
For compound 3 the middle estimate is 9.1-fold (0.96 log units) below the measured one; measured number outside the range, above it.
By their numbers in this assay, from the lowest: compound 1; then compound 2; then compound 3.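

Ethynyl in place of bromo, on the aromatic carbon next to the ring nitrogen and next to the ring sulfur, gives a 5.6-fold higher number from compound 2 to compound 3 (0.74 log units; beyond the scatter) in this assay, so compound 3 is the weaker inhibitor of this pair. Among the compounds shown here, compound 1 and compound 2 differ in more than one place, so this is the first single change that can be read here, and it shows that the group at this position matters for inhibition. Nothing available explains why this exchange weakens inhibition.

On these data alone, whether other groups at this position, such as an amine or a longer chain, would also weaken inhibition remains open. Also open, as far as these compounds go, is the effect of methyl here, since compound 1 carries it but differs from compound 2 and compound 3 in a second place too.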